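A few compounds are considered here, and "the series" means these few. Any claim that something is new, unique, unknown or untested is made for them only; others in the source may bear on it.

Three compounds built on one shared core were tested in a functional assay on A549 cells (Homo sapiens) for antiproliferative activity, read by MTT assay, with a stated time of 48 h; on this read-out higher numbers stand for weaker inhibition and lower numbers for stronger inhibition. Compound 1, `O=C(/C=C/c1ccc(C(F)(F)F)cc1)Nc1nnc(-c2ccccc2)s1`, gives 1.78 ug/mL. Compound 2, `COc1ccc(/C=C/C(=O)Nc2nnc(-c3ccccc3)s2)cc1`, differs from compound 1 by methoxy in place of trifluoromethyl on an aromatic carbon; compound 2 gives 0.76 ug/mL, a step of a 2.3-fold lower number from compound 1 to compound 2 (0.37 log units; beyond the scatter). Compound 3, `COc1ccc(-c2nnc(NC(=O)/C=C/c3ccc(C(F)(F)F)cc3)s2)cc1`, keeps the trifluoromethyl of compound 1 but carries the change methoxy in place of hydrogen on an aromatic carbon on the other ring; compound 3 gives 0.69 ug/mL, a step of a 2.6-fold lower number from compound 1 to compound 3 (0.41 log units; beyond the scatter). The numbers of compound 2 and compound 3 lie within the scatter of each other, so nothing can be read into their order.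

Compound 4, `COc1ccc(/C=C/C(=O)Nc2nnc(-c3ccc(OC)cc3)s2)cc1`, has not yet been measured. It differs from compound 3 by methoxy in place of trifluoromethyl on an aromatic carbon, the same change that turned compound 1 into compound 2, made at the same place. What differs between the two pairs is the core: compound 3 and compound 4 carry the change methoxy in place of hydrogen on an aromatic carbon where compound 1 and compound 2 carry hydrogen. The change has been seen only once among these compounds, so whether it carries over onto a core already bearing a methoxy is not known. The expectation is a 2.0-fold lower number from compound 3 to compound 4 (0.29 log units; within the scatter), because the same change produced a 2.3-fold lower number from compound 1 to compound 2 (0.37 log units; beyond the scatter) and the step is expected to be somewhat attenuated rather than fully repeated. Compound 4 is therefore expected to give 0.35 ug/mL, with a likely range from 0.15 ug/mL to 0.9 ug/mL.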

Compound 4, half-maximal inhibitory concentration: 0.52 ug/mL
Estimate against measurement, compound 4: 1.5-fold (0.17 log units) below; measured number inside the range.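

In this assay, methoxy in place of trifluoromethyl gives a 1.3-fold lower number from compound 3 to compound 4 (0.12 log units; within the scatter), and methoxy in place of hydrogen gives a 1.5-fold lower number from compound 2 to compound 4 (0.16 log units; within the scatter), so on the core that already carries the other methoxy, neither change stands clear of the usual scatter of repeated measurements. Each change stood beyond the scatter when first seen and within it here, which could suggest that it fades on the second core, but the gap between the two steps is too small to support that; the result shows no real difference between the cores, yet it does not prove that the change carries over in full, and for methoxy in place of trifluoromethyl the comparison reads: the same change on two cores in this assay, a 2.3-fold lower number (0.37 log units; beyond the scatter) from compound 1 to compound 2 and a 1.3-fold lower number (0.12 log units; within the scatter) from compound 3 to compound 4, 1.8-fold (0.25 log units) apart, within the scatter of two such steps The comparison for methoxy in place of hydrogen leads to the same cautious reading: the same change on two cores in this assay, a 2.6-fold lower number (0.41 log units; beyond the scatter) from compound 1 to compound 3 and a 1.5-fold lower number (0.16 log units; within the scatter) from compound 2 to compound 4, 1.8-fold (0.25 log units) apart, within the scatter of two such steps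

The compounds shown place only hydrogen, methoxy and trifluoromethyl on the two outer rings, so it stays open how an amine, a carboxylic acid or a longer chain such as ethoxy would behave at these places. From the compounds shown here alone, all four numbers come from this assay, and how these steps would look on other cells also stays open.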